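A few compounds are considered here, and "the series" means these few. Any claim that something is new, unique, unknown or untested is made for them only; others in the source may bear on it.

Compound 1 `CSCOC1(C)COC(C)(CC(=O)OC[C@H]2O[C@@H](n3cc(C)c(=O)[nH]c3=O)C[C@@H]2N=[N+]=[N-])C1`: 500000 nM
Compound 2 `CSCOC1(C)COC(C)(CC(=O)OC[C@@H]2C=C(O)[C@H](n3cnc4c(N)ncnc43)O2)C1`: 100000 nM
Compound 3 `CSCO[C@@]1(C)CO[C@@](C)(CC(=O)OC[C@H]2O[C@@H](n3cc(C)c(=O)[nH]c3=O)C[C@@H]2O[Si](C)(C)C(C)(C)C)C1`: 80000 nM

In a functional assay on JM1 cells (Homo sapiens) for cytotoxicity (a lower number here means that less compound is tolerated, a higher number that more compound is tolerated), compound 3 sits at 80000 nM. That is within the usual scatter of compound 2 and clearly lower than compound 1, beyond the scatter.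

Compound 4 `CSCO[C@@]1(C)CO[C@@](C)(CC(=O)OC[C@H]2O[C@@H](n3cc(C)c(=O)[nH]c3=O)C[C@@H]2O)C1` differs from compound 3 in one place: a hydrogen atom in place of a group of 7 heavy atoms (6 carbon, 1 silicon; no ring), on an oxygen on a saturated carbon. A hydrogen atom stands in place of a group of 7 heavy atoms, on an oxygen on a saturated carbon. Among the measured compounds shown here, no measured pair shows this change alone. Compound 1, at 500000 nM, shows that higher numbers occur among these compounds, so a modest rise is expected. The expected step is a 2.5-fold higher number from compound 3 to compound 4 (0.40 log units; beyond the scatter). For compound 4 the estimate is 200000 nM, with an expected range from 60000 nM to 600000 nM.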

Compound 4, half-maximal cytotoxic concentration: 400000 nM
Compound 4: the middle estimate sits 2.0-fold (0.30 log units) below what was measured; the range from low to high includes it.
By their numbers in this assay, from the lowest: compounds 3 and 2 (each within the scatter of the next); then compounds 4 and 1 (each within the scatter of the next).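

Among the compounds shown here, compound 3 and compound 4 form the first measured pair that differs in one place, so this oxygen on a saturated carbon can now be read directly. In this assay, a hydrogen atom in place of the group of 7 heavy atoms gives a 5.0-fold higher number from compound 3 to compound 4 (0.70 log units; beyond the scatter), so more compound is tolerated without that group. Nothing measured here accounts for this rise. Going by these compounds, it remains open whether a methyl or an acetyl group on this oxygen would give a number closer to compound 3 or to compound 4.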